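Amide substituent series: partition estimate for compound 4

This account rests on a few compounds, and the source may have more. Where it says the series, first, only, none or still open, it means among the compounds named here.

Compound 3 `COc1cc(-c2cc(C(=O)O)c3ccccc3n2)ccc1OCC(=O)NCc1ccccc1` stands lowest of the three measured compounds in a physicochemical assay for lipophilicity, using the shake flask method, in phosphate buffer, measured as octanol-water partition, at pH 7.4 (on this read-out lower numbers stand for lower lipophilicity and higher numbers for higher lipophilicity), where compound 3 gives 0.4. Compound 1 `COc1cc(-c2cc(C(=O)O)c3ccccc3n2)ccc1OCC(=O)Nc1ccccc1C` gives 0.8, and compound 2 `COc1cc(-c2cc(C(=O)O)c3ccccc3n2)ccc1OCC(=O)Nc1cccc(F)c1` gives 1.6. All three measured steps concern the group on the amide-type nitrogen: a number 0.80 log units higher from compound 1 to compound 2 (beyond the scatter), a number 0.40 log units lower from compound 1 to compound 3 (beyond the scatter) and a number 1.20 log units lower from compound 2 to compound 3 (beyond the scatter).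

Compound 4 `COc1cc(-c2cc(C(=O)O)c3ccccc3n2)ccc1OCC(=O)NCc1cccnc1` differs from compound 3 by pyridin-3-yl in place of phenyl on a saturated chain carbon bound to an amide-type nitrogen. Within the data shown here, none of the measured steps exchanges a ring carbon for a ring nitrogen, so no step covers this change directly; they show only that exchanges of the group on the amide-type nitrogen move this assay by modest to large amounts, within the span between compound 2 and compound 3. The direction has to be read from the counted difference alone, in which the entering pyridin-3-yl ring carries a hydrogen-bond acceptor where the leaving phenyl ring carries none. For compound 4 a step of a number 1.00 log units lower from compound 3 to compound 4 (beyond the scatter) in this assay is expected, beyond the scatter and downward. Compound 4 is therefore estimated at -0.6, with a range from -1.6 to 0.2.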

Compound 4, distribution coefficient: -0.8
Beside the measured number, compound 4's estimate is 0.20 log units above it; low and high end bracket the measured number.
By their numbers in this assay, from the lowest: compound 4; then compound 3; then compound 1; then compound 2.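

Among these compounds, with the saturated chain carbon kept, pyridin-3-yl in place of phenyl gives a number 1.20 log units lower from compound 3 to compound 4 (beyond the scatter) in this assay, so a change within the ring alone moves this read-out, whereas the earlier steps all exchanged one whole group on the amide-type nitrogen for another. That step matches in size the largest earlier one, a number 1.20 log units lower from compound 2 to compound 3 (beyond the scatter), and it widens the span at this position, with a number 2.40 log units lower from compound 2 to compound 4 (beyond the scatter) and a number 1.60 log units lower from compound 1 to compound 4 (beyond the scatter), leaving compound 4 lowest of the four in this assay. Nothing available explains the size of the step from phenyl to pyridin-3-yl.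

Still open, as far as these compounds go, is whether pyridin-2-yl or pyridin-4-yl on a saturated chain carbon bound to an amide-type nitrogen would give a step of similar size in this assay. Also open, from the compounds shown here alone, is whether the exchange of phenyl for pyridin-3-yl would read the same with 2-(pyridin-3-yl)ethyl, a longer chain, or with pyridin-3-yl directly on the amide-type nitrogen.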